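Saturated replacements for pyrimidinyl on the sulfonamide nitrogen

This account rests on a few compounds, and the source may have more. Where it says the series, first, only, none or still open, it means among the compounds named here.

Measured so far:
compound 1 `Cn1ccc2ccc(-c3cc(Nc4ccccc4S(=O)(=O)Nc4cncnc4)cc4nccnc34)cc21` gives 1690 nM in an assay for inhibition of 6-phosphofructo-2-kinase/fructose-2,6-bisphosphatase 3 (Homo sapiens), read by ADP-Glo, with a stated time of 2 h; a higher number here means a weaker inhibitor, a lower number a stronger inhibitor
compound 2 `CN1CCCC(NS(=O)(=O)c2ccccc2Nc2cc(-c3ccc4ccn(C)c4c3)c3nccnc3c2)C1` gives 59 nM in this assay

Going by the values given here, compound 1 holds the highest of the two numbers in this assay; the only measured step is a 29-fold lower number from compound 1 to compound 2 (1.46 log units; beyond the scatter), which came with 1-methylpiperidin-3-yl in place of pyrimidin-5-yl on a sulfonamide nitrogen. That step is large and beyond the scatter.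

Compound 3 `Cn1ccc2ccc(-c3cc(Nc4ccccc4S(=O)(=O)NCC4CCOCC4)cc4nccnc34)cc21` is not yet measured. It differs from compound 1 as (oxan-4-yl)methyl in place of pyrimidin-5-yl on a sulfonamide nitrogen. The change shares its main feature with the step to compound 2, a six-membered non-aromatic ring entering where the aromatic pyrimidin-5-yl leaves, but the entering group here carries an oxygen rather than a ring nitrogen and is attached through a methyl. Among the compounds with values here, only the one step bears on this, so the expectation for compound 3 is a lower number in this assay than for compound 1, direction borrowed from a 29-fold lower number from compound 1 to compound 2 (1.46 log units; beyond the scatter), with the size kept more cautious than that step.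

Compound 3 is therefore estimated at 300 nM, range 80 nM to 1200 nM, an expected 5.6-fold lower number from compound 1 to compound 3 (0.75 log units; beyond the scatter).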

Compound 3, half-maximal inhibitory concentration: 26 nM
For compound 3 the middle estimate is 12-fold (1.06 log units) above the measured one, outside the stated range (below it).
By their numbers in this assay, from the lowest: compound 3; then compound 2; then compound 1.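

In this assay, (oxan-4-yl)methyl on the sulfonamide nitrogen gives a 65-fold lower number from compound 1 to compound 3 (1.81 log units; beyond the scatter), so a large drop at this position does not depend on the ring nitrogen of 1-methylpiperidin-3-yl: a six-membered non-aromatic ring with an oxygen as its hetero atom also delivers it. The comparison between the two saturated groups gives a 2.3-fold lower number from compound 2 to compound 3 (0.36 log units; beyond the scatter), a modest step but beyond the scatter, which places compound 3 lowest of the three and shows that both non-aromatic replacements improve on pyrimidin-5-yl, with the oxygen-containing group ahead. No evidence is available on why either replacement lowers the number.

Compound 2 and compound 3 differ together in the ring hetero atom, the ring attachment and the presence of the methyl link, so these features cannot be separated from the compounds shown. On these data alone, it remains open how cyclohexylmethyl, oxan-4-yl joined to the sulfonamide nitrogen without the methyl link, or an open chain such as 2-methoxyethyl would compare with (oxan-4-yl)methyl.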